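This account rests on a few compounds, and the source may have more. Where it says the series, first, only, none or still open, it means among the compounds named here.

Working notes on the series.

Compound 1 `CCc1nc(N(CC2CC2)CC2CC2)c(CC)nc1-c1ccc(Cl)cc1Cl` and compound 2 `CCc1nc(-c2ccc(OC)cc2C(F)(F)F)c(CC)nc1NC(CC)CC` share a core that carries two ethyl groups, an aryl group and an amino group. Both have been tested in an assay on IMR-32 cells for displacement of a labelled ligand from corticotropin-releasing factor receptor 1 (Homo sapiens), read by scintillation counting, with a stated time of 2 h; a lower number here means a stronger inhibitor, a higher number a weaker inhibitor. Compound 1 gives 26 nM, the higher of the two numbers recorded so far. Compound 2 gives 4.4 nM, a lower number than compound 1 by a gap that lies beyond the scatter of repeated runs; it differs from compound 1 both in the aryl group and in the amino group, so its two values alone cannot be split between the two changes.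

Compound 3 `CCc1nc(-c2ccc(Cl)cc2Cl)c(CC)nc1NC(CC)CC` keeps the 2,4-dichlorophenyl group of compound 1 and takes the amino group seen in compound 2. For the measured compounds named here, the single change from compound 1 to compound 3 is (pentan-3-yl)amino in place of bis(cyclopropylmethyl)amino on an aromatic carbon.

Going by the values given here, with no single-point step measured, the only pointer is that compound 2, which carries the (pentan-3-yl)amino group, gives 4.4 nM. A step from compound 1 to compound 3 in this assay of moderate size toward a lower number is expected, a 2.9-fold lower number from compound 1 to compound 3 (0.46 log units; beyond the scatter), while a change within the scatter is also possible. Compound 3 is estimated at 9 nM, within 3 nM to 27 nM.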

Compound 3, inhibition constant: 4.1 nM
Estimate against measurement, compound 3: 2.2-fold (0.34 log units) above, within the range that was stated.
By their numbers in this assay, from the lowest: compounds 3 and 2 (each within the scatter of the next); then compound 1.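

The amino group alone moves the number in this assay: (pentan-3-yl)amino in place of bis(cyclopropylmethyl)amino, on the aromatic carbon para to the 2,4-dichlorophenyl group, gives a 6.3-fold lower number from compound 1 to compound 3 (0.80 log units; beyond the scatter). For the compounds shown here, with (pentan-3-yl)amino held, compound 3 at 4.1 nM and compound 2 at 4.4 nM lie within the scatter of each other, so the two aryl groups show no separation in this pair. The change removes both three-membered rings and adds a hydrogen-bond donor, and no measurement at hand links the step to either feature.

On these data alone, it remains open whether the step follows the hydrogen-bond donor, the loss of the rings or the smaller group, and a methyl(pentan-3-yl)amino group or a cyclopropylmethylamino group at the same carbon would help to separate these. Also open, as far as these compounds go, is whether a step of this size holds with the aryl group of compound 2, since bis(cyclopropylmethyl)amino appears here only with the 2,4-dichlorophenyl group.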